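Fluoro in place of isobutoxy: working notes

This account rests on a few compounds, and the source may have more. Where it says the series, first, only, none or still open, it means among the compounds named here.

- compound 1 `CC(C)COc1ccc2oc(/C=C/[S+](C)[O-])cc(=O)c2c1`: 5000 nM
- compound 2 `Cc1c(/C=C/[S+](C)[O-])oc2ccccc2c1=O`: 7200 nM

In a functional assay on DLD-1 cells (Homo sapiens) for cytotoxicity, with a stated time of 48 h (a lower number here means a stronger inhibitor, a higher number a weaker inhibitor), compound 1 and compound 2 lie within the usual scatter of each other, so compound 1 does not stand apart. Compound 3 `C[S+]([O-])/C=C/c1cc(=O)c2cc(F)ccc2o1` has not yet been measured. It carries fluoro in place of isobutoxy on an aromatic carbon. Within the data shown here, no step between measured compounds is available to size this change. Compound 2, which also has no isobutoxy, gives 7200 nM, so no shift beyond the scatter is expected. The expected step is a 1.4-fold higher number from compound 1 to compound 3 (0.15 log units; within the scatter), an estimate that stays within the scatter. For compound 3 the estimated value is 7000 nM, with an expected range of 2500 nM to 20000 nM.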

Compound 3, half-maximal inhibitory concentration: 7000 nM
Compound 3: middle estimate and measured number agree at the digits printed; the range from low to high includes it.
By their numbers in this assay, from the lowest: compounds 1, 3 and 2 (each within the scatter of the next).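

In this assay, fluoro in place of isobutoxy on this aromatic carbon gives a 1.4-fold higher number from compound 1 to compound 3 (0.15 log units; within the scatter), the first step sized at this position. Losing the isobutoxy chain and its hydrogen-bond acceptor therefore leaves the number within the scatter, so isobutoxy is not required for the cytotoxicity of compound 1. No supporting measurement bears on this result.

Going by these compounds, whether an amine or a carboxylic acid on this carbon would move the number beyond the scatter remains open. So does the outcome for a chain longer than isobutoxy.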